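The source may hold more compounds than are shown below. What is called first, only, known or untested is meant among the compounds shown, and "the series" means these compounds.

Compound 1 `Cc1cc(NC(=O)Nc2ccc(C(=O)O)cc2)c2ccccc2n1` gives in an ADME assay on HepG2 cells (Homo sapiens) for cytotoxicity, with a stated time of 72 h (on this read-out lower numbers stand for an effect already at smaller amounts and higher numbers for an effect only at larger amounts of compound), only the limit > 25000 nM, not a number.
Compound 2 `Cc1cc(NC(=O)Nc2ccccc2C(F)(F)F)c2ccccc2n1` gives in this assay only the limit > 25000 nM, not a number.
Compound 3 `Cc1cc(NC(=O)Nc2cccc([N+](=O)[O-])c2)c2ccccc2n1` gives in this assay only the limit > 25000 nM, not a number.

Compound 2 therefore does not stand at a measured point at all: its result is a limit, and the same holds for the two other compounds shown, so all three values sit at the limit of > 25000 nM in this assay, at which 3 of the 3 values shown sit. Going by the values given here, no step between two measured compounds is known here, so the spread of a change on the shared core cannot yet be read from the data.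

Compound 4 `Cc1cc(NC(=O)Nc2ccccc2[N+](=O)[O-])c2ccccc2n1` is the next compound of the series. Compared with compound 2 the structure changes as follows: nitro in place of trifluoromethyl on an aromatic carbon. Among the compounds with values here, with every compound so far resting at the same limit, the expected step from compound 2 to compound 4 in this assay is none beyond the scatter, a step that the limit leaves unreadable from compound 2 to compound 4. Compound 4 is therefore estimated at 40000 nM, with a range from 20000 nM to 100000 nM, most likely again reported as a limit rather than a number.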

Compound 4, half-maximal effective concentration: > 25000 nM
Compound 4 gave a limit, no number; the forecaster's own chance of this, stated with the estimate: 85%; the middle value lies beyond the limit too.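

Compound 2 and compound 4 each give only a limit in this assay, so nitro in place of trifluoromethyl yields no readable step. The compounds shown leave open at what concentration any of them would show an effect, and whether their groups make any difference, as all rest at one value: the limit of > 25000 nM in this assay, at which 4 of the 4 values shown sit.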